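The source may hold more compounds than are shown below. What is called first, only, known or untested is meant among the compounds shown, and "the series" means these compounds.

In a functional assay on A2780 cells (Homo sapiens) for antiproliferative activity, read by MTT assay, with a stated time of 48 h (a lower number here means a stronger inhibitor, a higher number a weaker inhibitor), three compounds have been measured so far. Compound 1 `CCNCC(=O)Nc1cc(OC)ccc1C(=O)c1ccc(OC)c2c1C=CC(C)(C)O2` gives 4090 nM and compound 2 `COc1ccc(C(=O)c2ccc3c(c2)C=CC(C)(C)O3)c(NC(=O)CN(C)C)c1` gives 1020 nM, while compound 3 `COc1ccc(C(=O)c2cc(OC)c(OC)c(OC)c2)c(NC(=O)CO)c1` gives 100 nM and has the lowest number of the three. Its gaps to compound 2, the nearest, and to compound 1, the furthest, both lie beyond the scatter.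

Compound 4 `COc1ccc(C(=O)c2cc(OC)c(OC)c(OC)c2)c(NC(=O)CN(C)C)c1` keeps the core of compound 3 and differs in one place: dimethylamino in place of hydroxy on a saturated chain carbon bound to a carbonyl carbon.

For the measured compounds named here, no two measured compounds differ in only one place, so the size of this change has not been seen directly. The closest hint is compound 2, which carries the same dimethylamino group on another core and gives a higher number (1020 nM). Its core differs from that of compound 3, so it is only a weak guide. A modest rise in this assay is therefore expected, toward weaker inhibition, and a step within the scatter remains possible. The estimated change is a 2.2-fold higher number from compound 3 to compound 4 (0.34 log units; beyond the scatter). The expected value for compound 4 is 220 nM within an estimated range of 50 nM to 1000 nM until the measurement is in.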

Compound 4, half-maximal inhibitory concentration: 580 nM
The estimate for compound 4 lay 2.6-fold (0.42 log units) below the measured number, within the range that was stated.
By their numbers in this assay, from the lowest: compound 3; then compounds 4 and 2 (each within the scatter of the next); then compound 1.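

In this assay the exchange of hydroxy for dimethylamino on a saturated chain carbon bound to a carbonyl carbon can now be read directly on a single core, and it gives a 5.8-fold higher number from compound 3 to compound 4 (0.76 log units; beyond the scatter) with nothing else in the structure altered. This place is therefore not indifferent to the change: on this core, the stronger inhibitor carries hydroxy, with 1 heavy atom and 1 hydrogen-bond donor, and the weaker carries dimethylamino, with 3 heavy atoms and 0 hydrogen-bond donors. No measurement bearing on the cause of this step is available, so the data do not separate the roles of these differences.

As far as these compounds go, all of this rests on one pair of compounds, so it remains open whether the same exchange would give a step of similar size on another core. The compounds shown also leave open how this place responds to other groups, such as a primary amine, a methoxy group, a carboxylic acid or a longer chain ending in hydroxy.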